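Trypsin Counter-Screen: From Lactam to Imidazole

The compounds below may be only part of what the source reports. "The series", "measured", "known", "first", "only" and "open" are said of these compounds alone.

Compound 1 `Cc1nn(-c2ccc3onc(N)c3c2)c2c(F)c(-c3ccc(N4CCCCC4=O)cc3F)ccc12`: > 10000 nM
Compound 2 `NC(=O)c1nn(-c2ccc3onc(N)c3c2)c2c(F)c(-c3ccc(N4CCCCC4=O)cc3F)ccc12`: > 10000 nM

In an assay on isolated protein for inhibition of Trypsin (Homo sapiens) (a lower number here means a stronger inhibitor, a higher number a weaker inhibitor), compound 1 gives > 10000 nM, which is a limit of the assay rather than a number. Compound 2 likewise gives > 10000 nM, again a limit of the assay. The step that the two limits leave unreadable from compound 1 to compound 2 is thus unreadable, and all evidence is confined to the limit of > 10000 nM in this assay, at which 2 of the 2 values shown sit. Compound 3 `CN(C)Cc1nccn1-c1ccc(-c2ccc3c(C(N)=O)nn(-c4ccc5onc(N)c5c4)c3c2F)c(F)c1` differs from compound 2 by 2-((dimethylamino)methyl)-1H-imidazol-1-yl in place of 2-oxopiperidin-1-yl on an aromatic carbon. For the measured compounds named here, no measured step bears on this change, and compound 2 stands only at a limit, so in this assay no step beyond the scatter can be expected in either direction. Compound 3 is therefore estimated at 10000 nM, within 2000 nM to 50000 nM. The expected step is a number no higher from compound 2 to compound 3 (the limit leaves the size open).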

Compound 3, inhibition constant: > 10000 nM
Compound 3 gave a limit, no number; the forecaster's own chance of this, stated with the estimate: 70%; the middle value sits exactly at the limit.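

In this assay, compound 3 gives a limit and not a number, as compound 2 does, so no step can be read between compound 2 and compound 3. The compounds shown leave open how strongly any of them actually inhibits, with all the evidence resting on one limit: the limit of > 10000 nM in this assay, at which 3 of the 3 values shown sit.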